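This account rests on a few compounds, and the source may have more. Where it says the series, first, only, none or still open, it means among the compounds named here.

Within the data shown here, compound 1 `Cc1cccc(N2C(=O)CSC2c2cccc(C(=O)NCCCCc3ccccc3)c2)c1` is one of two compounds measured so far on a shared core. In a functional assay on SJSA-1 cells (Homo sapiens) for inhibition, read by CCK-8 assay, with a stated time of 72 h, tested at 1 uM (a lower number here means less inhibition, a higher number more inhibition at the concentration tested (going by the name of the read-out)), compound 1 gives 84%; this is the smaller of the two numbers in hand, but the gap to compound 2 `CCOc1ccccc1N1C(=O)C(C)SC1c1cccc(C(=O)NCCCCc2ccccc2)c1`, which gives 85% in this assay, lies within the usual scatter, so the two cannot be told apart. Compound 3 `COc1ccc(N2C(=O)CSC2c2cccc(C(=O)NCCCCc3ccccc3)c2)c(OC)c1` has not yet been measured. It differs from compound 1 in a single place: 2,4-dimethoxyphenyl in place of 3-methylphenyl on an amide-type nitrogen in a ring. Among the measured compounds shown here, no pair of measured compounds shows what such a change does in this assay, and compound 2 tells only that a different substituent at this part of the core gave a matching number. Compound 3 is therefore expected to stay close to compound 1, with a step of a number 6 percentage points lower from compound 1 to compound 3 (within the scatter) that is expected to lie within the scatter. The value estimated for compound 3 in this assay is 78%, with a range from 55% to 95%.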

Compound 3, a percentage reported as inhibition, at one concentration (the size of the read-out at that concentration, not a potency): 85%
For compound 3 the middle estimate is 7 percentage points below the measured one, within the range that was stated.
By their numbers in this assay, from the lowest: compounds 1, 2 and 3 (each within the scatter of the next).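

Among these compounds, this is the first direct reading of a change at this place: in this assay, 2,4-dimethoxyphenyl in place of 3-methylphenyl on the amide-type nitrogen in a ring gives a number 1 percentage points higher from compound 1 to compound 3 (within the scatter). At this place, then, the step from 7 to 10 heavy atoms and from 0 to 2 hydrogen-bond acceptors leaves compound 3 indistinguishable from compound 1 in this read-out. Nothing in hand explains why the number holds across this change.

Still open, as far as these compounds go, is what a group of another kind would do on this nitrogen, such as a phenyl ring carrying a carboxylic acid or an aminomethyl group, or a longer alkyl chain in place of the ring. From the compounds shown here alone, whether compound 1 and compound 3 also match in potency stays open too, as a read-out at one concentration is not a potency.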